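A few compounds are considered here, and "the series" means these few. Any claim that something is new, unique, unknown or untested is made for them only; others in the source may bear on it.

Of the compounds shown here, three have been tested for their effect on the growth of human skin cells, measured in an ADME assay on HFF cells (Homo sapiens) for cytotoxicity; a lower number here means a stronger inhibitor, a higher number a weaker inhibitor. Compound 1, with the structure `CCNc1ncnc2c1c(Br)cn2COC(CO)CO`, gives only a limit of the assay in this assay, namely > 100000 nM. Compound 2, with the structure `CCNc1ncnc2c1c(Cl)cn2COC(CO)CO`, likewise gives only a limit in this assay, namely > 100000 nM. Compound 3, with the structure `OCC(CO)OCn1cc(Cl)c2c(NO)ncnc21`, also gives only a limit in this assay, namely > 100000 nM.

Two of these compounds differ in one place from compound 2. The first change, (bromo in place of chloro on an aromatic carbon), made the step that the two limits leave unreadable from compound 2 to compound 1. The second change, (hydroxy in place of ethyl on a nitrogen on an aromatic ring), made the step that the two limits leave unreadable from compound 2 to compound 3. Both steps are unreadable because of the limit of > 100000 nM in this assay, at which 3 of the 3 values shown sit.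

The unmeasured compound 4 has the structure `OCC(CO)OCn1cc(Br)c2c(NO)ncnc21`. Going by the values given here, it differs from compound 3 by bromo in place of chloro on an aromatic carbon, and this is the same change as the one from compound 2 to compound 1, at a place described in the same words. The two cores, those of compound 3 and compound 2, differ by hydroxy in place of ethyl on a nitrogen on an aromatic ring. Since the earlier step from compound 2 to compound 1 stayed within the limit, the step from compound 3 to compound 4 is expected to be a number no higher from compound 3 to compound 4 (the limit leaves the size open). Compound 4 is therefore estimated to give about 100000 nM in this assay, most likely again as a limit, within a range of 50000 nM to 300000 nM.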

Compound 4, half-maximal inhibitory concentration: > 100000 nM
Compound 4: a limit, no number (the forecaster's own chance of this, stated with the estimate: 85%); the middle value sits exactly at the limit.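

No new step can be read between compound 1, compound 3 and compound 4, because compound 4 also gives only a limit and no number: the limit of > 100000 nM in this assay, at which 4 of the 4 values shown sit.

In this assay the compounds shown leave open whether bromo in place of chloro, or hydroxy in place of ethyl on the nitrogen, changes inhibition at all, and how strongly any of these compounds inhibits.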